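Cyclopropyl for Isopropyl on the Amine Nitrogen

This account rests on a few compounds, and the source may have more. Where it says the series, first, only, none or still open, it means among the compounds named here.

In a functional assay on HCT-116 cells (Homo sapiens) for inhibition, read by MTT assay, with a stated time of 72 h (a higher number here means a weaker inhibitor, a lower number a stronger inhibitor), compound 1 `COc1cc(Oc2cccc(Nc3ccccc3)c2)cc(OC)c1CNCc1ccc(F)cc1` gives 4220 nM. Compound 2 `CNCc1c(OC)cc(Oc2cccc(Nc3ccccc3)c2)cc1OC` reads > 20000 nM, which is a limit of the assay and not a number. Compound 3 `COc1cc(Oc2cccc(Nc3ccccc3)c2)cc(OC)c1CNC(C)C` reads > 20000 nM, and this too is only a limit.

Removing the 4-fluorobenzyl group from the amine nitrogen was costly both times it was measured. The data show an at least 4.7-fold higher number from compound 1 to compound 2 (0.67 log units; beyond the scatter), and also an at least 4.7-fold higher number from compound 1 to compound 3 (0.67 log units; beyond the scatter). Between the two small groups, methyl and isopropyl, there is a step that the two limits leave unreadable from compound 2 to compound 3.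

Compound 4 `COc1cc(Oc2cccc(Nc3ccccc3)c2)cc(OC)c1CNC1CC1` carries cyclopropyl in place of isopropyl on an amine nitrogen. Like compound 3, it lacks the 4-fluorobenzyl group, so the loss seen in an at least 4.7-fold higher number from compound 1 to compound 3 (0.67 log units; beyond the scatter) is expected to hold here as well. No clear change in either direction is therefore expected, and the estimated step is a number no higher from compound 3 to compound 4 (the limit leaves the size open). The estimate for compound 4 is 20000 nM, with an expected range of 9000 nM to 40000 nM.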

Compound 4, half-maximal inhibitory concentration: > 20000 nM
Compound 4: no number, only a limit; the forecaster's own chance of this, stated with the estimate: 75%; the middle value sits exactly at the limit.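

In this assay, compound 4 gives > 20000 nM, which is a limit of the assay and not a number. Cyclopropyl in place of 4-fluorobenzyl brings an at least 4.7-fold higher number from compound 1 to compound 4 (0.67 log units; beyond the scatter), so a small group containing a ring joins methyl and isopropyl in falling short of compound 1 on this amine nitrogen. The steps among compound 2, compound 3 and compound 4 cannot be read, because all three values sit at the same limit: the limit of > 20000 nM in this assay, at which 3 of the 4 values shown sit.

From the compounds shown here alone, it remains open whether the activity of compound 1 depends on the whole 4-fluorobenzyl group or mainly on its fluorine, and a plain benzyl group on this nitrogen would separate the two. A longer chain ending in phenyl would show whether the distance from the nitrogen to the aromatic ring matters as well.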